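Chloro to Methyl on the Fused Ring of Compound 2

The source may hold more compounds than are shown below. What is called first, only, known or untested is meant among the compounds shown, and "the series" means these compounds.

Compound 1 `O=C(Nc1nc2ccccc2s1)c1cn(-c2ccccc2)nc1-c1ccc(F)cc1` gives 10700 nM in a functional assay on U-87MG ATCC cells for cytotoxicity against U-87 MG (Homo sapiens), read by MTT assay, with a stated time of 72 h; on this read-out lower numbers stand for stronger inhibition and higher numbers for weaker inhibition.
Compound 2 `O=C(Nc1nc2ccc(Cl)cc2s1)c1cn(-c2ccccc2)nc1-c1ccc(F)cc1` gives 6770 nM in this assay.

For the measured compounds named here, the two numbers measured so far are separated by a step of a 1.6-fold lower number from compound 1 to compound 2 (0.20 log units; within the scatter), so the two compounds cannot be ranked on this read-out. Compound 3 `Cc1ccc2nc(NC(=O)c3cn(-c4ccccc4)nc3-c3ccc(F)cc3)sc2c1` has not yet been measured in this assay. It differs from compound 2 in one place: methyl in place of chloro on an aromatic carbon. Going by the values given here, the only measured step, a 1.6-fold lower number from compound 1 to compound 2 (0.20 log units; within the scatter), exchanged hydrogen for chloro on the shared core and stayed within the scatter; it bears on the present change only loosely, since here a methyl takes the place of that chloro rather than hydrogen. With a single step of that size to go on, no shift beyond the scatter is foreseen. Compound 3 is therefore expected to show a step of a 1.1-fold higher number from compound 2 to compound 3 (0.04 log units; within the scatter) against compound 2, nothing beyond the usual spread. The estimate for compound 3 in this assay is 7500 nM, with a range from 3500 nM to 16000 nM.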

Compound 3, half-maximal inhibitory concentration: > 50000 nM
Compound 3: only a limit was reported; the forecaster's own chance of this, stated with the estimate: 5%; middle value at least 6.6-fold (0.82 log units) from the limit.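

The earlier pair gave this aromatic carbon no readable influence in this assay, with a 1.6-fold lower number from compound 1 to compound 2 (0.20 log units; within the scatter), whereas the new compound separates from both of its neighbours: the exchange of chloro for methyl gives an at least 7.3-fold higher number from compound 2 to compound 3 (0.86 log units; beyond the scatter), and methyl in place of hydrogen gives an at least 4.6-fold higher number from compound 1 to compound 3 (0.66 log units; beyond the scatter). The reading for compound 3 is a limit of the assay and not a number: the limit of > 50000 nM in this assay, at which 1 of the 3 values shown sits. The position is therefore not indifferent to what it carries: the exchange of one heavy atom for another, with no ring, hydrogen-bond donor, hydrogen-bond acceptor or net charge entering or leaving, separates compound 3 from compound 2, and methyl stands apart from chloro and hydrogen, which themselves cannot be ranked.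

The compounds shown do not tell why methyl departs from both hydrogen and chloro, and the full size of both new steps stays unfixed. On these data alone, it also remains open whether a methoxy group, a fluoro or an amine on the same carbon would fall with compound 3 or with compound 1 and compound 2, and whether the loss with methyl would persist with other groups elsewhere on the shared core.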